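Cytotoxicity limits from compound 2 to compound 3

The source may hold more compounds than are shown below. What is called first, only, known or untested is meant among the compounds shown, and "the series" means these compounds.

In an ADME assay on MT4 cells (Homo sapiens) for cytotoxicity, read by MTT assay (a higher number here means that more compound is tolerated, a lower number that less compound is tolerated), compound 2 `Cc1cc(C)cc(S(=O)(=O)c2c(C(=O)Nc3cc(C#N)ccn3)[nH]c3ccc(Cl)cc23)c1` gives > 53700 nM as a limit and not a number. Compound 1 `Cc1cc(C)cc(S(=O)(=O)c2c(C(=O)NCC(=O)NCc3ccco3)[nH]c3ccc(Cl)cc23)c1` gives > 50000 nM as a limit too. Compound 3 `Cc1cc(C)cc(S(=O)(=O)c2c(C(=O)NCC(=O)NCc3ccncn3)[nH]c3ccc(Cl)cc23)c1` brings a group of 11 heavy atoms (7 carbon, 3 nitrogen, 1 oxygen; one six-membered aromatic ring with 2 hetero atoms) in place of a group of 8 heavy atoms (6 carbon, 2 nitrogen; one six-membered aromatic ring with 1 hetero atom), on an amide-type nitrogen as its change on an amide-type nitrogen. The step that the two limits leave unreadable from compound 1 to compound 2 is the only measured one that bears on this, and it has no readable size, so no step beyond the scatter is expected in this assay here. The estimated step is an at least 1.0-fold lower number from compound 2 to compound 3 (0.03 log units; that floor lies within the scatter) and no more is expected. Compound 3 is expected at 50000 nM with an estimated range from 20000 nM to 100000 nM in this read-out.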

Compound 3, half-maximal cytotoxic concentration: > 48800 nM
Compound 3: a limit, no number; the forecaster's own chance of this, stated with the estimate: 85%; the middle value is on the limit's open side.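

Going by these compounds alone, compound 1, compound 2 and compound 3 all give limits and not numbers in this assay; no step among them can be read. Still open, on these data alone, is where any of the three would reach half-maximal cytotoxicity, and whether the changes on the amide-type nitrogen shift it.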